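The source may hold more compounds than are shown below. What is called first, only, known or untested is meant among the compounds shown, and "the series" means these compounds.

Series notes. Compound 1 `COc1ccc2cc(-c3cccc(-c4ccncc4)c3)ccc2c1` and compound 2 `Oc1ccc2cc(-c3cccc(-c4cccnc4)c3)ccc2c1` have both been run in an assay for inhibition of steroid 17-alpha-hydroxylase/17,20 lyase (Homo sapiens), tested at 2 uM; on this read-out higher numbers stand for a stronger effect at the one concentration tested and lower numbers for a weaker effect. In this assay compound 1 gives 23%, and compound 2 gives 8%, the lower of the two numbers, with compound 1 standing higher by more than the usual scatter. The two differ from each other in two places at once, so no single step can be read off between them.

Compound 3 `Oc1ccc2cc(-c3cccc(-c4ccncc4)c3)ccc2c1` has not yet been measured. It departs from compound 2 by one change: pyridin-4-yl in place of pyridin-3-yl on an aromatic carbon. For the measured compounds named here, the only measured compound carrying pyridin-4-yl is compound 1, which gives 23% in this assay, and this is the sole hint on direction. An upward step of moderate size is expected, a number 12 percentage points higher from compound 2 to compound 3 (beyond the scatter), resting on compound 1 at 23%. Compound 3 is accordingly estimated at 20% in this assay, within a range of 5% to 38%, the width reflecting that a single other compound informs the guess and that compound 1 also differs from compound 3 elsewhere.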

Compound 3, a percentage reported as inhibition, at one concentration (the size of the read-out at that concentration, not a potency): 66%
Beside the measured number, compound 3's estimate is 46 percentage points below it; the measured number lies above the stated range.
By their numbers in this assay, from the lowest: compound 2; then compound 1; then compound 3.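

Working notes on the series. In this assay, the ring nitrogen's placement matters strongly: with the rest of the structure held constant and no change in the counts of atoms, donors or acceptors, pyridin-4-yl in place of pyridin-3-yl on an aromatic carbon gives a number 58 percentage points higher from compound 2 to compound 3 (beyond the scatter). The oxygen substituent matters as well: with pyridin-4-yl held constant, hydrogen in place of methyl on an oxygen on an aromatic ring gives a number 43 percentage points higher from compound 1 to compound 3 (beyond the scatter). Compound 3 therefore stands above each of its two single-change neighbours by a large step, a relationship that the gap between compound 1 and compound 2, which differ in two places at once, could not show.

The compounds shown leave open whether the pyridin-4-yl gain carries over to a methyl ether partner of compound 2, and what pyridin-2-yl, or an amine or a carboxylic acid on the ring in place of the hydroxyl, would give; since each number comes from one concentration, it speaks only of a stronger or weaker effect at that concentration. Nothing available here accounts for the size of either step.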